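This account rests on a few compounds, and the source may have more. Where it says the series, first, only, none or still open, it means among the compounds named here.

Three measured compounds share one core and differ only in the group carried on the nitrogen attached to that core. In a functional assay on CHO-K1 cells for antagonist activity at adenosine receptor A2b (Homo sapiens), read by FLIPR and calcium flux (a lower number here means a stronger inhibitor, a higher number a weaker inhibitor), compound 1 `CCNc1nc(C(=O)c2ccc(C)s2)c2sccc2n1` gives 1260 nM. Compound 2 `Cc1ccc(C(=O)c2nc(NCc3ccccc3)nc3ccsc23)s1` gives 5580 nM in this assay, and compound 3 `Cc1ccc(C(=O)c2nc(NCc3ccccn3)nc3ccsc23)s1` gives 43 nM. Compound 3 thus stands lowest of the three numbers: the step of a 29-fold lower number from compound 1 to compound 3 (1.47 log units; beyond the scatter) and the step of a 130-fold lower number from compound 2 to compound 3 (2.11 log units; beyond the scatter) both lie well beyond the scatter, while the step of a 4.4-fold higher number from compound 1 to compound 2 (0.65 log units; beyond the scatter) was modest and ran the other way.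

Compound 4 `Cc1ccc(C(=O)c2nc(NC(=O)c3cccnc3)nc3ccsc23)s1` has not yet been measured. It differs from compound 3 by (pyridin-3-yl)carbonyl in place of (pyridin-2-yl)methyl on a nitrogen on an aromatic ring. Within the data shown here, no measured step makes exactly this change. The nearest lessons are that a 130-fold lower number from compound 2 to compound 3 (2.11 log units; beyond the scatter) was large, so exchanging the aromatic ring at that place moved the number a great deal, and that a 29-fold lower number from compound 1 to compound 3 (1.47 log units; beyond the scatter) shows the pyridin-2-yl group in particular going with the low number. Among the measured compounds shown here, compound 4 gives up that group and also trades the saturated chain carbon for a carbonyl, with no measured precedent for either move. Compound 4 is therefore expected to give a markedly higher number, an estimated step of a 35-fold higher number from compound 3 to compound 4 (1.54 log units; beyond the scatter). Compound 4 is estimated at 1500 nM, with a likely range from 250 nM to 9000 nM.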

Compound 4, half-maximal inhibitory concentration: 287 nM
For compound 4 the middle estimate is 5.2-fold (0.72 log units) above the measured one; the measured number falls inside the stated range.
By their numbers in this assay, from the lowest: compound 3; then compound 4; then compound 1; then compound 2.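

The nitrogen on the shared core keeps much of its low number in this assay even when the saturated chain carbon gives way to a carbonyl and pyridin-2-yl gives way to pyridin-3-yl, for the double change costs only a modest step, a 6.7-fold higher number from compound 3 to compound 4 (0.82 log units; beyond the scatter). A low number is therefore not tied to (pyridin-2-yl)methyl alone: the new group still shows a large step against benzyl, a 19-fold lower number from compound 2 to compound 4 (1.29 log units; beyond the scatter), and a modest one against ethyl, a 4.4-fold lower number from compound 1 to compound 4 (0.64 log units; beyond the scatter). Among these four compounds, the two carrying a pyridinyl group hold the two lowest numbers, with no compound going against that pattern, but no supporting evidence is available to explain it.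

Compound 4 changes both the link and the ring at once. The data do not show how much of the step goes with each change; (pyridin-3-yl)methyl or (pyridin-2-yl)carbonyl on the same nitrogen would separate the two. Benzoyl at that place would likewise show what the carbonyl does when no ring nitrogen is present.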